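Substituted Phenyl Rings and Amylase Inhibition: Compound 4

The source may hold more compounds than are shown below. What is called first, only, known or untested is meant among the compounds shown, and "the series" means these compounds.

Compound 1 `CC(=O)N1N=C(c2ccc(-n3nc(C)n(N)c3=O)cc2)CC1c1ccccc1`: in an assay on isolated protein for inhibition of pancreatic alpha-amylase (Homo sapiens), with a stated time of 10 min, tested at 1 mg/mL (on this read-out lower numbers stand for less inhibition and higher numbers for more inhibition at the one concentration tested (going by the name of the read-out)), compound 1 gives 129%
Compound 2 `CC(=O)N1N=C(c2ccc(-n3nc(C)n(N)c3=O)cc2)CC1c1cccc(Cl)c1`: in this assay compound 2 gives 96.5%
Compound 3 `CC(=O)N1N=C(c2ccc(-n3nc(C)n(N)c3=O)cc2)CC1c1ccc(C)cc1`: in this assay compound 3 gives 96.5%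

Compound 3 stands level with compound 2, the two together being the lowest of the three numbers, while compound 1 lies higher by a number 32.5 percentage points lower from compound 1 to compound 3 (beyond the scatter). Compound 4 `CC(=O)N1N=C(c2ccc(-n3nc(C)n(N)c3=O)cc2)CC1c1ccccc1Cl` differs from compound 3 in one place: 2-chlorophenyl in place of 4-methylphenyl on a saturated ring carbon. Among the compounds with values here, two measured steps bear on it. Placing a chloro group on the phenyl ring gave a number 32.5 percentage points lower from compound 1 to compound 2 (beyond the scatter), and a methyl group gave a number 32.5 percentage points lower from compound 1 to compound 3 (beyond the scatter); exchanging one substituted ring for the other gave no change at the digits printed from compound 2 to compound 3 (within the scatter). A chlorine at a new position is therefore expected to leave compound 3 within the scatter, an expected step of a number 0.5 percentage points lower from compound 3 to compound 4 (within the scatter). Compound 4 is estimated at 96%, in the range 80% to 115%.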

Compound 4, a percentage reported as inhibition, at one concentration (the size of the read-out at that concentration, not a potency): 76.7%
The estimate for compound 4 lay 19.3 percentage points above the measured number, outside the stated range (below it).
By their numbers in this assay, from the lowest: compound 4; then compounds 2 and 3 (each within the scatter of the next); then compound 1.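

In this assay, the placing of the chlorine on this phenyl ring proves to matter: 2-chlorophenyl in place of 3-chlorophenyl gives a number 19.8 percentage points lower from compound 2 to compound 4 (beyond the scatter) on the same saturated ring carbon. The level shared by compound 2 and compound 3 therefore does not hold for every substituted ring, since 2-chlorophenyl in place of 4-methylphenyl gives a number 19.8 percentage points lower from compound 3 to compound 4 (beyond the scatter) and chloro in place of hydrogen gives a number 52.3 percentage points lower from compound 1 to compound 4 (beyond the scatter) here. Substitution on this ring lowered the number in all three cases.

From the compounds shown here alone, whether a methoxy group or an amine on this ring would give a similar number remains open. Nothing at hand explains the difference between the chlorophenyl rings.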